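Aryl amine variation on a shared core

The compounds below may be only part of what the source reports. "The series", "measured", "known", "first", "only" and "open" are said of these compounds alone.

Measured so far:
compound 1 `CCOC(=O)C1=C(C)NC(=S)NC1c1cn(C(=O)CNc2ccccc2)c2ccccc12`: 52 ug/mL
compound 2 `CCOC(=O)C1=C(C)NC(=O)NC1c1cn(C(=O)CNc2ccc([N+](=O)[O-])cc2Cl)c2ccccc12`: 50 ug/mL
compound 3 `CCOC(=O)C1=C(C)NC(=S)NC1c1cn(C(=O)CNc2ccc([N+](=O)[O-])cc2C)c2ccccc12`: 48 ug/mL

All three numbers in a functional assay on MCF7 cells (Homo sapiens) for cytotoxicity, read by MTT assay, with a stated time of 72 h (on this read-out higher numbers stand for weaker inhibition and lower numbers for stronger inhibition), sit close together. Compound 2 falls in the middle of the three, with compound 1 on one side and compound 3 on the other, but it is separated from neither beyond the scatter.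

Compound 4 `CCOC(=O)C1=C(C)NC(=O)NC1c1cn(C(=O)CNc2ccc(Cl)cc2)c2ccccc12` is the next member and is not yet measured. Relative to compound 2 the change is 4-chlorophenyl in place of 2-chloro-4-nitrophenyl on an amine nitrogen.

Among the compounds with values here, the one measured step that bears on this change varies the aryl group on the same amine nitrogen: a 1.1-fold lower number from compound 1 to compound 3 (0.03 log units; within the scatter). Within the data shown here, compound 2 and compound 3 differ at that aryl group and also elsewhere, so no single step is attributed to that pair; their two values simply lie within the scatter of each other. Among the measured compounds shown here, nothing so far shows that the aryl group on the amine moves the number beyond the scatter, so no step beyond the scatter is expected in this assay for compound 4, in either direction, and the step from compound 2 is estimated as no change at the digits printed from compound 2 to compound 4 (within the scatter).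

For compound 4 the expected value in this assay is 50 ug/mL, with a range from 28 ug/mL to 90 ug/mL.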

Compound 4, half-maximal inhibitory concentration: 200 ug/mL
The estimate for compound 4 lay 4.0-fold (0.60 log units) below the measured number, outside the stated range (above it).
By their numbers in this assay, from the lowest: compounds 3, 2 and 1 (each within the scatter of the next); then compound 4.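

In this assay, the aryl group on the amine nitrogen proves able to move the number: 4-chlorophenyl in place of 2-chloro-4-nitrophenyl gives a 4.0-fold higher number from compound 2 to compound 4 (0.60 log units; beyond the scatter), toward weaker inhibition. Within the data shown here, the only earlier step at this nitrogen, a 1.1-fold lower number from compound 1 to compound 3 (0.03 log units; within the scatter), showed no such shift, so this position is not indifferent to its aryl group, at least on the core of compound 2. Nothing measured in the series accounts for the step.

The change alters the aryl group in more than one way at once, so the compounds shown do not separate the loss of the nitro group from the different chlorine placement. Going by these compounds, how a methoxy group or a carboxylic acid on the same phenyl ring would read also remains open.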